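The source may report more compounds than this note shows. Statements on the series, on what has been measured and on what is new or still open speak of the compounds shown alone.

Compound 1 (`CC(=O)[C@H]1[C@@H](O)CCC2=C[C@H](O)C[C@H](C)[C@]21C`) gives > 5 ug/mL in a functional assay on HT-29 cells (Homo sapiens) for cytotoxicity (a higher number here means that more compound is needed for the effect, a lower number that less compound is needed), as a limit of the assay and not a number. Compound 2 (`CC(=O)[C@H]1C(=O)CCC2=C[C@@H](O)C[C@H](C)[C@]21C`) likewise gives > 5 ug/mL as a limit in this assay and no number. Compound 3 (`CC(=O)[C@H]1[C@H](O)CCC2=C[C@@H](O)C[C@H](C)[C@]21C`) has not yet been measured, and its change from compound 1 is that the two compounds have the same atoms and bonds and differ only in configuration as drawn: 2 of 5 stereo elements differ; a stereocentre at a saturated ring carbon is drawn S in compound 1 and R in compound 3; a stereocentre at a saturated ring carbon is drawn R in compound 1 and S in compound 3 (nothing else differs). Going by the values given here, no measured step is available as a guide, so no shift beyond the scatter is expected in this assay and the estimated step is a step that the limit leaves unreadable from compound 1 to compound 3 (in no clear direction). Compound 3 is expected at 6 ug/mL with an estimated range from 2.5 ug/mL to 15 ug/mL in this assay.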

Compound 3, concentration for half-maximal effect: > 5 ug/mL
Compound 3 ended at the assay's limit (the forecaster's own chance of this, stated with the estimate: 75%); the middle value does not contradict the limit.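

No step can be read from compound 1 to compound 3, as both stand at a limit of the assay: the limit of > 5 ug/mL in this assay, at which 3 of the 3 values shown sit. On these data alone, whether the configuration separating compound 1 from compound 3 changes the result in this assay remains open.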